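The compounds below may be only part of what the source reports. "The series", "measured", "known", "first", "only" and "open" are said of these compounds alone.

Among the measured compounds shown here, in a functional assay on MCF7 cells (Homo sapiens) for antiproliferative activity, read by MTT assay, with a stated time of 72 h (a lower number here means a stronger inhibitor, a higher number a weaker inhibitor), compound 3 (`CCN(CC)CCNC(=O)c1cc(C(CC)(CC)c2ccc(C#CC(O)(CC)CC)c(C)c2)cn1CC`) gives 1800 nM, the lowest number so far. Compound 1 (`CCn1c(C(=O)N[C@H](C(=O)O)C(C)C)ccc1C(CC)(CC)c1ccc(C#CC(O)(CC)CC)c(C)c1`) gives 13000 nM, a higher number, beyond the scatter. Compound 2 (`CCn1c(C(=O)NCCC(=O)O)ccc1C(CC)(CC)c1ccc(C#CC(O)(CC)CC)c(C)c1`) gives > 50000 nM, which is a limit of the assay and not a number.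

Compound 4 (`CCn1cc(C(CC)(CC)c2ccc(C#CC(O)(CC)CC)c(C)c2)cc1C(=O)N[C@H](C(=O)O)C(C)C`) keeps the core of compound 3 and changes only the group on the amide-type nitrogen: 1-carboxy-2-methylpropyl in place of 2-(diethylamino)ethyl on an amide-type nitrogen. The entering 1-carboxy-2-methylpropyl also stands in compound 1, but on a core that differs from that of compound 3. For the measured compounds named here, the one measured step, an at least 3.8-fold higher number from compound 1 to compound 2 (0.58 log units; beyond the scatter), replaces that group with 2-carboxyethyl. It shows that the group on this nitrogen can move the number in this assay, but it does not measure the present exchange. The closest guide is compound 1 at 13000 nM, so a rise beyond the scatter is expected. The expected change is a 6.7-fold higher number from compound 3 to compound 4 (0.82 log units; beyond the scatter). For compound 4 the estimated value is 12000 nM, with an expected range of 4000 nM to 40000 nM.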

Compound 4, half-maximal inhibitory concentration: 12600 nM
Compound 4: middle estimate off by 1.1-fold (0.02 log units), on the low side, and the stated range covers the measured number.
By their numbers in this assay, from the lowest: compound 3; then compounds 4 and 1 (each within the scatter of the next). At a limit, above all of these: compound 2.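

On the core of compound 3, the group on the amide-type nitrogen moves the number in this assay: the exchange gives a 7.0-fold higher number from compound 3 to compound 4 (0.85 log units; beyond the scatter). The earlier step compared two carboxy-bearing groups on the core of compound 1, whereas this one sets 2-(diethylamino)ethyl against 1-carboxy-2-methylpropyl on a single core, with the lower number on the 2-(diethylamino)ethyl side. The data shown offer no measured property that accounts for this step.

On these data alone, it remains open whether the difference follows the tertiary amine, the carboxylic acid or both, and a plain alkyl chain or a primary amine on the same nitrogen would separate these. As far as these compounds go, a longer chain ahead of the diethylamino end, and 2-(diethylamino)ethyl on the core of compound 1, also remain open.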